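This account rests on a few compounds, and the source may have more. Where it says the series, first, only, none or still open, it means among the compounds named here.

Measured in a physicochemical assay for solubility, read by HPLC, measured as kinetic solubility; a higher number here means a more soluble compound, a lower number a less soluble compound:
- Compound 1 `NC(=O)c1cc(-c2ccccc2)cc2c(C3CCN(S(=O)(=O)CCCNC4CCCC4)CC3)c[nH]c12`: 85000 nM
- Compound 2 `NC(=O)c1cc(-c2ccccc2)cc2c(C3CCN(S(=O)(=O)CCCN4CCCCCC4)CC3)c[nH]c12`: 93000 nM
- Compound 3 `NC(=O)c1cc(-c2ccccc2)cc2c(C3CCN(S(=O)(=O)CCCN4CCCC4)CC3)c[nH]c12`: 185000 nM

Compound 3 stands at the upper end of these numbers, with a 2.2-fold higher number from compound 1 to compound 3 (0.34 log units; beyond the scatter) and a 2.0-fold higher number from compound 2 to compound 3 (0.30 log units; within the scatter). Compound 4 `CCN(CC)CCCS(=O)(=O)N1CCC(c2c[nH]c3c(C(N)=O)cc(-c4ccccc4)cc23)CC1` puts diethylamino in place of pyrrolidin-1-yl, on a saturated chain carbon, three bonds along the chain from a sulfonyl sulfur: diethylamino in place of pyrrolidin-1-yl on a saturated chain carbon, three bonds along the chain from a sulfonyl sulfur. For the measured compounds named here, no measured step makes this exact swap. The closest evidence is the other changes at this place, which stay small, as with a 1.1-fold higher number from compound 1 to compound 2 (0.04 log units; within the scatter). The two steps into compound 3 suggest a slight drop when pyrrolidin-1-yl leaves, but nothing large. The expected change is a 1.4-fold lower number from compound 3 to compound 4 (0.15 log units; within the scatter). Compound 4 is estimated at 130000 nM, with an expected range of 70000 nM to 240000 nM.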

Compound 4, solubility: 173000 nM
Beside the measured number, compound 4's estimate is 1.3-fold (0.12 log units) below it, within the range that was stated.
By their numbers in this assay, from the lowest: compounds 1, 2, 4 and 3 (each within the scatter of the next, the first and the last beyond it).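

In this assay, diethylamino in place of pyrrolidin-1-yl gives a 1.1-fold lower number from compound 3 to compound 4 (0.03 log units; within the scatter), so at this position an open-chain amine matches the ring within the scatter. Diethylamino in place of azepan-1-yl gives a 1.9-fold higher number from compound 2 to compound 4 (0.27 log units; within the scatter), and only diethylamino in place of cyclopentylamino, at a 2.0-fold higher number from compound 1 to compound 4 (0.31 log units; beyond the scatter), passes the scatter. Nothing measured here explains these steps. Every group shown at this place is an amine, so it remains open how a morpholine or a carboxylic acid on the same chain would read.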